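Adding a Second Carboxymethyl Arm to Compound 3

The source may report more compounds than this note shows. Statements on the series, on what has been measured and on what is new or still open speak of the compounds shown alone.

Compound 3 `O=C(O)CNC(=O)CN(c1nc(Cl)nc2[nH]cnc12)C1CC1` is the starting point. In a functional assay on the whole organism (Tail, strain ICR) with Mus musculus as the target, in the tail flick test, with a stated time of 60 min, at a dose of 25 umol/kg by the oral route (on this read-out higher numbers stand for a stronger effect at the one dose given and lower numbers for a weaker effect), compound 3 gives 38.9%, a number that lies among the three measured values with every neighbour inside the usual scatter. Compound 1 `O=C(O)[C@@H]1CCCN1C(=O)CN(c1nc(Cl)nc2[nH]cnc12)C1CC1` gives 34.9%, and compound 2 `O=C(CN(c1nc(Cl)nc2[nH]cnc12)C1CC1)NCC(=O)OCc1ccccc1` gives 41.9%. Replacing the 2-carboxypyrrolidin-1-yl group with a (carboxymethyl)amino group gave a number 4 percentage points higher from compound 1 to compound 3 (within the scatter), and replacing benzyl with hydrogen on the oxygen gave a number 3 percentage points lower from compound 2 to compound 3 (within the scatter). Neither change moved the read-out beyond the scatter.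

Compound 4 `O=C(O)C[C@H](NC(=O)CN(c1nc(Cl)nc2[nH]cnc12)C1CC1)C(=O)O` differs from compound 3 in one place: carboxymethyl in place of hydrogen on a saturated chain carbon bound to an amide-type nitrogen and a carbonyl carbon. The two measured steps bear on this change, since both alter the part of the molecule that carries the carboxylic acid, and both stayed within the scatter. No step beyond the scatter is therefore expected in this assay, in either direction. Compound 4 is estimated at 39%, with a range from 25% to 53%. This estimate means an expected step of a number 0.1 percentage points higher from compound 3 to compound 4 (within the scatter), which should stay within the scatter.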

Compound 4, a percentage reported as activity, at one dose (the size of the read-out at that dose, not a potency): 38.9%
Estimate against measurement, compound 4: 0.1 percentage points above; measured number inside the range.
By their numbers in this assay, from the lowest: compounds 1, 3, 4 and 2 (each within the scatter of the next).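

In this assay, carboxymethyl in place of hydrogen on a saturated chain carbon bound to an amide-type nitrogen and a carbonyl carbon gives no change at the digits printed from compound 3 to compound 4 (within the scatter) and stays within the scatter. Among the compounds shown here, the earlier steps swapped the whole 2-carboxypyrrolidin-1-yl group or removed benzyl from the oxygen, whereas this one adds a group to this carbon for the first time. This carbon therefore accepts carboxymethyl, with its 4 heavy atoms, without the read-out at this one dose moving beyond the scatter, and nothing at hand explains that result.

On these data alone, whether an amine or a longer chain ending in a carboxylic acid would behave the same way on this carbon remains open. So does whether the benzyl ester of carboxymethyl would read like compound 4 here.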